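Amine-substituted lactone series: aryl swap at the amine nitrogen

This account rests on a few compounds, and the source may have more. Where it says the series, first, only, none or still open, it means among the compounds named here.

Going by the values given here, in a functional assay on KB cells (Homo sapiens) for cytotoxicity, read by sulforhodamine B assay (on this read-out higher numbers stand for weaker inhibition and lower numbers for stronger inhibition), compound 2 `C=C1[C@@H](OC(C)=O)C[C@@H]2[C@](C)(COC=O)[C@H](OC(C)=O)CC[C@@]2(C)[C@@H]1C[C@@H](Nc1ccc(Br)cc1)C1=CCOC1=O` gives 24000 nM, the highest of the three numbers so far. Among the compounds with values here, compound 1 `C=C1[C@@H](OC(C)=O)C[C@@H]2[C@](C)(CO[Si](C)(C)C(C)(C)C)[C@H](OC(C)=O)CC[C@@]2(C)[C@@H]1C[C@@H](Nc1ccccc1F)C1=CCOC1=O` gives 4740 nM and compound 3 `C=C1[C@@H](OC(C)=O)C[C@@H]2[C@](C)(CO[Si](C)(C)C(C)(C)C)[C@H](OC(C)=O)CC[C@@]2(C)[C@@H]1C[C@@H](Nc1ccc(C(=O)O)cc1)C1=CCOC1=O` gives 5540 nM in this assay, both lower than compound 2 by more than the scatter; each of them differs from compound 2 in two places, so no single step links them to compound 2. Within the data shown here, the only single-point step so far, a 1.2-fold higher number from compound 1 to compound 3 (0.07 log units; within the scatter), swaps the aryl group on the amine nitrogen and stays within the scatter.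

Compound 4 `C=C1[C@@H](OC(C)=O)C[C@@H]2[C@](C)(COC=O)[C@H](OC(C)=O)CC[C@@]2(C)[C@@H]1C[C@@H](Nc1cccc2ccccc12)C1=CCOC1=O` keeps the core of compound 2 and differs from it only at the amine nitrogen: naphthalen-1-yl in place of 4-bromophenyl on an amine nitrogen. Among the measured compounds shown here, no measured step covers a bromophenyl-to-naphthyl exchange at this position. For the measured compounds named here, the one aryl exchange on record, a 1.2-fold higher number from compound 1 to compound 3 (0.07 log units; within the scatter), moved nothing beyond the scatter, so compound 4 is expected to sit close to compound 2, with no change at the digits printed from compound 2 to compound 4 (within the scatter) expected to fall within the scatter. The estimate for compound 4 in this assay is 24000 nM, with an expected range of 8000 nM to 70000 nM.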

Compound 4, half-maximal inhibitory concentration: 32300 nM
For compound 4 the middle estimate is 1.3-fold (0.13 log units) below the measured one; low and high end bracket the measured number.
By their numbers in this assay, from the lowest: compounds 1 and 3 (each within the scatter of the next); then compounds 2 and 4 (each within the scatter of the next).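

In this assay, naphthalen-1-yl in place of 4-bromophenyl on the amine nitrogen gives a 1.3-fold higher number from compound 2 to compound 4 (0.13 log units; within the scatter), so on the core of compound 2 a second aromatic ring and the loss of the bromine leave the number within the scatter. With a 1.2-fold higher number from compound 1 to compound 3 (0.07 log units; within the scatter) on the core of compound 1, both aryl exchanges shown at this nitrogen, each on a different core, stay within the scatter. Nothing at hand bears on the reason for this result.

On these data alone, only aryl groups appear on this nitrogen, so it remains open whether a cyclohexyl group, a longer alkyl chain or an acyl group forming an amide would give a similar number. The separate contribution of the silyl ether and the formate also remains open, as no pair shown differs only there.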